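A third halogenated aryl group on the shared core

The compounds below may be only part of what the source reports. "The series", "measured", "known", "first", "only" and "open" are said of these compounds alone.

Compound 1 `Fc1ccc(C2=NN(C(=S)Nc3ccccc3)C(c3ccc4c(c3)OCCO4)C2)cc1` gives 22500 nM in a functional assay on WM 266-4 cells (Homo sapiens) for antiproliferative activity, read by MTT assay, with a stated time of 48 h; a lower number here means a stronger inhibitor of growth, a higher number a weaker inhibitor of growth. Compound 2 `S=C(Nc1ccccc1)N1N=C(c2ccccc2Br)CC1c1ccc2c(c1)OCCO2` reaches only a limit of this assay, > 200000 nM. Compound 2 therefore stands at the weak end of the two values shown, sitting at the limit described by the limit of > 200000 nM in this assay, at which 1 of the 2 values shown sits. Among the measured compounds shown here, the step of an at least 8.8-fold higher number from compound 1 to compound 2 (0.94 log units; beyond the scatter) is the only measured change that bears on the aryl group. Compound 3 `S=C(Nc1ccccc1)N1N=C(c2cccc(Cl)c2)CC1c1ccc2c(c1)OCCO2` differs from compound 2 by 3-chlorophenyl in place of 2-bromophenyl on a carbon with a double bond to nitrogen. For the measured compounds named here, no measured step matches this change, so compound 3 is expected near 60000 nM, in a range from 15000 nM to 250000 nM. The expected step is estimated as an at least 3.3-fold lower number from compound 2 to compound 3 (0.52 log units; beyond the scatter).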

Compound 3, concentration for 50% growth inhibition: > 200000 nM
Compound 3 ended at the assay's limit; the forecaster's own chance of this, stated with the estimate: 35%; middle value at least 3.3-fold (0.52 log units) away from the limit.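

Replacing 4-fluorophenyl with 3-chlorophenyl gives, in this assay, an at least 8.8-fold higher number from compound 1 to compound 3 (0.94 log units; beyond the scatter). This is a second aryl change at this position that moves the number beyond the scatter, and the step between the two limit compounds cannot be read. Two different halogenated aryl groups now end at the same limit: the limit of > 200000 nM in this assay, at which 2 of the 3 values shown sit.

Each change alters both the halogen and its place on the phenyl ring, and the compounds shown cannot separate the two. Also open, as far as these compounds go, is how an amine or a carboxylic acid on this phenyl ring would fare.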